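This account rests on a few compounds, and the source may have more. Where it says the series, first, only, none or still open, it means among the compounds named here.

Of the compounds shown here, three have so far been measured in a functional assay on U-937 cells (Homo sapiens) for cytotoxicity, read by MTT assay, with a stated time of 48 h; on this read-out lower numbers stand for stronger inhibition and higher numbers for weaker inhibition. Compound 1 `Fc1cccc(-c2nc(Nc3ccccc3)c3ccccc3n2)c1` reaches only a limit of this assay, > 50000 nM. Compound 2 `Fc1ccc2nc(-c3ccccc3)nc(Nc3ccccc3)c2c1` likewise stops at a limit, > 50000 nM. Within the data shown here, compound 3 `Fc1cccc(-c2nc(Nc3ccc(Cl)cc3)c3cc(F)ccc3n2)c1` is the one compound with a number: in this assay compound 3 gives 32700 nM. Where compound 3 stands is therefore plain: it carries the only value that is a number, while the other two results are limits, a point summed up by the limit of > 50000 nM in this assay, at which 2 of the 3 values shown sit. Compound 4 `Oc1ccccc1Nc1nc(-c2cccc(F)c2)nc2ccc(F)cc12` has not yet been measured in this assay. It differs from compound 3 in one place: 2-hydroxyphenyl in place of 4-chlorophenyl on a nitrogen on an aromatic ring. Among the measured compounds shown here, no two measured compounds differ in a single place, so no measured step shows how such a change moves the number. What is expected is a step of a 1.1-fold lower number from compound 3 to compound 4 (0.04 log units; within the scatter), which stays within the usual scatter, with a real chance that the result comes back as a limit. Compound 4 is therefore estimated at 30000 nM in this assay, with a range from 8000 nM to 50000 nM.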

Compound 4, half-maximal inhibitory concentration: 46300 nM
Estimate against measurement, compound 4: 1.5-fold (0.19 log units) below; the range from low to high includes it.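

In this assay, among these compounds, this is the first measured change at a single place, and it gives a 1.4-fold higher number from compound 3 to compound 4 (0.15 log units; within the scatter), so 2-hydroxyphenyl and 4-chlorophenyl on this nitrogen cannot be told apart. The swap removes a chlorine and brings in a hydrogen-bond donor and a hydrogen-bond acceptor, yet in this one pair the number does not move beyond the scatter. Compound 3 and compound 4 are the two results given as numbers, while the other two results are limits: the limit of > 50000 nM in this assay, at which 2 of the 4 values shown sit.

A single pair cannot show whether this place tolerates change in general or whether both groups simply leave the compound weak. From the compounds shown here alone, whether an amine or a carboxylic acid on this ring, or a longer chain on the nitrogen, would shift the number beyond the scatter remains open.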